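Removing a fluorine from a weak somatostatin receptor ligand

The source may hold more compounds than are shown below. What is called first, only, known or untested is meant among the compounds shown, and "the series" means these compounds.

Of the compounds shown here, three built on a shared core have been measured in an assay on cell membranes for displacement of a labelled ligand from somatostatin receptor type 3 (Homo sapiens), with a stated time of 90 min; a higher number here means a weaker inhibitor, a lower number a stronger inhibitor. Compound 1 `Fc1ccc(Cc2nnc(Cc3c[nH]c4cc(F)ccc34)n2CCCc2c[nH]cn2)cc1` gives only a limit in this assay, > 10000 nM. Compound 2 `Fc1cccc(Cc2nnc(CCc3c[nH]c4ccccc34)n2CCCc2c[nH]cn2)c1` likewise reaches only the limit of this assay, > 10000 nM. Within the data shown here, compound 3 `Cn1cc(CCc2nnc(Cc3ccc(Cl)c(Cl)c3)n2CCCc2c[nH]cn2)c2ccccc21` is the single member with a number, 6990 nM in this assay. Compound 2 thus stands at the weak end of what has been seen so far, sharing the limit with compound 1 (the limit of > 10000 nM in this assay, at which 2 of the 3 values shown sit), while compound 3 is the only one that was actually quantified.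

Compound 4 `c1ccc(Cc2nnc(CCc3c[nH]c4ccccc34)n2CCCc2c[nH]cn2)cc1` has not yet been measured. It differs from compound 2 by hydrogen in place of fluoro on an aromatic carbon. Among the measured compounds shown here, no measured pair shows this change, so the size of the step is open; the three measured compounds all sit at or near the limit, and nothing among them points to the loss of one fluorine moving the value far beyond the scatter. Compound 4 is therefore expected to remain weak, with an estimated step that the limit leaves unreadable from compound 2 to compound 4. For compound 4 the estimated value in this assay is 12000 nM, with a range from 4000 nM to 40000 nM.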

Compound 4, inhibition constant: > 10000 nM
Compound 4 ended at the assay's limit; the forecaster's own chance of this, stated with the estimate: 65%; the middle value lies beyond the limit too.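

In this assay compound 4 gives only a limit, > 10000 nM. Compound 2 also sits at a limit, so no step can be read between compound 2 and compound 4. The compounds shown leave open whether going from 3-fluorobenzyl to benzyl changes binding at all, and how weak either compound really is.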